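Removing the Nitro Group from a Macrocyclic Amide

The compounds below may be only part of what the source reports. "The series", "measured", "known", "first", "only" and "open" are said of these compounds alone.

Three macrocyclic amides have been tested in a functional assay on cell membranes from cells (Erythrocyte, Homo sapiens), read by spectrophotometry, with a stated time of 30 min, tested at 10 ug/mL; on this read-out higher numbers stand for a stronger effect at the one concentration tested and lower numbers for a weaker effect. Compound 1 `O=C1NCc2ccc(cc2)-c2cccc(c2)-c2ccc(cc2)CNC(=O)c2cccc(c2)OCc2ccc(cc2)COc2cccc1c2` gives 57.6%. Compound 2 `O=C1NCc2ccc(cc2)-c2cccc(c2)-c2ccc(cc2)CNC(=O)c2cccc(c2)OCc2ccccc2-c2ccccc2COc2cccc1c2` gives 70.3%. Compound 3 `O=C1NCc2ccc(cc2)-c2cccc(c2)-c2ccc(cc2)CNC(=O)c2cccc(c2)OCc2cc(cc([N+](=O)[O-])c2)COc2cccc1c2` gives 66.7%. Among these three numbers compound 3 stands second highest; the nearest is compound 2, whose value is somewhat higher, and the furthest is compound 1, whose value is lower, yet both gaps lie within the scatter of this kind of measurement, so no order among the three can be claimed.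

Compound 4 `O=C1NCc2ccc(cc2)-c2cccc(c2)-c2ccc(cc2)CNC(=O)c2cccc(c2)OCc2cccc(c2)COc2cccc1c2` has not yet been measured. It differs from compound 3 in one place: hydrogen in place of nitro on an aromatic carbon. Among the compounds with values here, no step between measured compounds that differ in a single place is available to guide the expectation. Because the three measured values of compound 1, compound 2 and compound 3 all sit within the scatter of one another, the expected step of a number 4.7 percentage points lower from compound 3 to compound 4 (within the scatter) in this assay is small, none beyond the scatter in either direction. Compound 4 is therefore estimated at 62%, with a range from 47% to 77%.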

Compound 4, a percentage reported as activity, at one concentration (the size of the read-out at that concentration, not a potency): 64.3%
Estimate against measurement, compound 4: 2.3 percentage points below, within the range that was stated.
By their numbers in this assay, from the lowest: compounds 1, 4, 3 and 2 (each within the scatter of the next, the first and the last beyond it).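

Within the data shown here, replacing nitro with hydrogen on this aromatic carbon gives, in this assay, a number 2.4 percentage points lower from compound 3 to compound 4 (within the scatter), and this is the first step that isolates a single place. With the core held constant, the removal of three heavy atoms and two hydrogen-bond acceptors at this position leaves compound 3 and compound 4 indistinguishable on this read-out, so the nitro group shows no measurable contribution here at the one concentration tested. No measurement shown offers an explanation for this result.

From the compounds shown here alone, it remains open whether an amine or a carboxylic acid on this same aromatic carbon would also stay within the scatter of compound 4. These single-concentration values also leave open whether compound 3 and compound 4 would still match at other concentrations.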